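Swapping methoxy for chloro on a selenocyanate carbamate

The source may report more compounds than this note shows. Statements on the series, on what has been measured and on what is new or still open speak of the compounds shown alone.

Compound 1 `COc1ccc(OC(=O)Nc2ccc([Se]C#N)cc2)cc1`, an ADME assay on BEAS-2B cells (Homo sapiens) for cytotoxicity, read by MTT assay, with a stated time of 72 h; a higher number here means a weaker inhibitor of growth, a lower number a stronger inhibitor of growth: 48400 nM
Compound 2 `CCOC(=O)Nc1ccc([Se][Se]c2ccc(NC(=O)OCC)cc2)cc1`, this assay: 44000 nM
Compound 3 `CCCCCCOC(=O)Nc1ccc([Se][Se]c2ccc(NC(=O)OCCCCCC)cc2)cc1`, this assay: 6900 nM

Among the three measured compounds, compound 1 gives the highest number in this assay, meaning it is the weakest inhibitor of growth in the set. Compound 2 sits so close that the two cannot be told apart within the usual scatter. Compound 3 lies clearly lower, beyond the scatter, so it inhibits growth more strongly than compound 1.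

Compound 4 `N#C[Se]c1ccc(NC(=O)Oc2ccc(Cl)cc2)cc1` has not yet been measured. It differs from compound 1 in one place: chloro in place of methoxy on an aromatic carbon. Among the compounds with values here, no measured pair in this set shows the effect of such a swap, so there is no directly comparable step to lean on.

The expectation is that the step from compound 1 to compound 4 in this assay stays within the scatter, a 1.2-fold lower number from compound 1 to compound 4 (0.08 log units; within the scatter), with no clear direction. On that basis compound 4 is estimated at 40000 nM, within a range from 15000 nM to 100000 nM.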

Compound 4, concentration for total growth inhibition: 38000 nM
Beside the measured number, compound 4's estimate is 1.1-fold (0.02 log units) above it; the measured number falls inside the stated range.
By their numbers in this assay, from the lowest: compound 3; then compounds 4, 2 and 1 (each within the scatter of the next).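

This pair gives the set its first direct view of this position. In this assay, putting chloro in place of methoxy on an aromatic carbon, para to a large group, gives a 1.3-fold lower number from compound 1 to compound 4 (0.11 log units; within the scatter). Methoxy brings two heavy atoms and one hydrogen-bond acceptor, while chloro brings one heavy atom and no acceptor, yet this difference produces no shift that can be separated from ordinary repeat variation, and no supporting measurement is available to explain the result.

A single swap cannot show how much this position matters in general. Going by these compounds, an amine, a carboxylic acid or a longer alkoxy chain at the same place could still move the number beyond the scatter, and whether any of them would remains open.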